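From 4-fluorophenyl to 3-bromophenyl on the sulfonyl sulfur

A few compounds are considered here, and "the series" means these few. Any claim that something is new, unique, unknown or untested is made for them only; others in the source may bear on it.

In a functional assay on HeLa cells (Homo sapiens) for cytotoxicity, read by sulforhodamine B assay (on this read-out higher numbers stand for weaker inhibition and lower numbers for stronger inhibition), compound 3 `CC(NS(=O)(=O)c1ccc(F)cc1)C1=CC(=O)c2c(O)ccc(O)c2C1=O` gives 6410 nM. That is level, within the scatter, with compound 2 `COc1ccc(S(=O)(=O)NC(C)C2=CC(=O)c3c(O)ccc(O)c3C2=O)cc1` at 3760 nM, while compound 1 `CC(C)C(NS(=O)(=O)c1cccc(Br)c1)C1=CC(=O)c2c(O)ccc(O)c2C1=O` gives a clearly lower 860 nM. Compound 4 `CC(NS(=O)(=O)c1cccc(Br)c1)C1=CC(=O)c2c(O)ccc(O)c2C1=O` has 3-bromophenyl in place of 4-fluorophenyl on a sulfonyl sulfur. Among the compounds with values here, the only measured step at this place, a 1.7-fold higher number from compound 2 to compound 3 (0.23 log units; within the scatter), is small. Within the data shown here, no measured step isolates the 3-bromophenyl group itself, but compound 1 also carries it and gives 860 nM, so a modest move toward lower numbers seems likely. The expected step is a 1.8-fold lower number from compound 3 to compound 4 (0.26 log units; within the scatter). The estimate for compound 4 is 3500 nM, with an expected range from 1300 nM to 8000 nM.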

Compound 4, half-maximal inhibitory concentration: 6350 nM
The estimate for compound 4 lay 1.8-fold (0.26 log units) below the measured number, and the stated range covers the measured number.
By their numbers in this assay, from the lowest: compound 1; then compounds 2, 4 and 3 (each within the scatter of the next).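

In this assay the group on the sulfonyl sulfur matters little here: a 1.0-fold lower number from compound 3 to compound 4 (0.00 log units; within the scatter) and a 1.7-fold higher number from compound 2 to compound 4 (0.23 log units; within the scatter) are both within the scatter, so 3-bromophenyl, 4-fluorophenyl and 4-methoxyphenyl cannot be told apart when the chain carries methyl. The clear change comes with methyl in place of isopropyl, a 7.4-fold higher number from compound 1 to compound 4 (0.87 log units; beyond the scatter), so the low number of compound 1 does not follow from its 3-bromophenyl group alone. No measurement shown explains this difference. Going by these compounds, whether these aryl groups would also stay level with isopropyl on the chain remains open. So does the effect of a longer chain, such as butyl, at that carbon.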